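The source may hold more compounds than are shown below. What is called first, only, known or untested is meant among the compounds shown, and "the series" means these compounds.

Measured so far:
compound 1 `CC(C)=CCN(C)C1CCN(CCCc2c[nH]c3ccc(-n4cnnc4)cc23)CC1`: 0.5 nM
compound 2 `CN(CC1CCN(CCCc2c[nH]c3ccc(-n4cnnc4)cc23)CC1)C(=O)Nc1ccccc1`: 5.9 nM

In an assay on CHO cells for displacement of a labelled ligand from 5-hydroxytryptamine receptor 1D (Homo sapiens) (on this read-out lower numbers stand for stronger inhibition and higher numbers for weaker inhibition), compound 1 has the lowest number of the two, and compound 2 stands higher, beyond the usual scatter. Compound 3 `CN(Cc1cccs1)C1CCN(CCCc2c[nH]c3ccc(-n4cnnc4)cc23)CC1` is not yet measured. It differs from compound 1 in one place: thiophen-2-yl in place of 2-methylprop-1-en-1-yl on a saturated chain carbon bound to an amine nitrogen. Among the measured compounds shown here, no step between measured compounds isolates such a change, so the expectation rests on compound 1 alone and on the nearness of the groups in size. A small step toward a higher number is expected, a 2.4-fold higher number from compound 1 to compound 3 (0.38 log units; beyond the scatter), at the edge of the scatter. Compound 3 is therefore estimated at 1.2 nM, between 0.3 nM and 5 nM.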

Compound 3, half-maximal inhibitory concentration: 4.3 nM
Compound 3: the middle estimate sits 3.6-fold (0.55 log units) below what was measured; measured number inside the range.
By their numbers in this assay, from the lowest: compound 1; then compounds 3 and 2 (each within the scatter of the next).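

In this assay, replacing the 2-methylprop-1-en-1-yl with thiophen-2-yl gives an 8.6-fold higher number from compound 1 to compound 3 (0.93 log units; beyond the scatter). This shows that the number responds to the group at this place, on a saturated chain carbon bound to an amine nitrogen, and that an aromatic ring there is tolerated, with compound 3 still at 4.3 nM. Nothing measured here explains the step.

Still open, as far as these compounds go, is whether any aromatic ring would give a similar number, or whether the outcome is particular to thiophen-2-yl. A phenyl or furan-2-yl group at this place would help to separate the two.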